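Heterocycle variation on the amine-bound methylene: compound 4

The source may hold more compounds than are shown below. What is called first, only, known or untested is meant among the compounds shown, and "the series" means these compounds.

Measured so far in an assay on HEK293 cells for displacement of a labelled ligand from growth hormone secretagogue receptor type 1 (Homo sapiens), with a stated time of 60 min; a higher number here means a weaker inhibitor, a lower number a stronger inhibitor:
compound 1 `COc1cccc(-n2cc3nc(-c4cccnc4C)n(C[C@H]4CCCN(CC5CCOC5)C4)c(=O)c3n2)c1` gives 60 nM
compound 2 `COc1cccc(-n2cc3nc(-c4cccnc4C)n(C[C@H]4CCCN(CC5CCCCO5)C4)c(=O)c3n2)c1` gives 120 nM
compound 3 `COc1cccc(-n2cc3nc(-c4cccnc4C)n(C[C@H]4CCCN(CC5CCO5)C4)c(=O)c3n2)c1` gives 23 nM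

Compound 3 has the lowest number of the three in this assay; its gap to compound 1 and to compound 2 is beyond the scatter in each case, so it is the strongest inhibitor of the measured set. Compound 4 `COc1cccc(-n2cc3nc(-c4cccnc4C)n(C[C@H]4CCCN(Cc5cnco5)C4)c(=O)c3n2)c1` is not yet measured. It differs from compound 3 in one place: 1,3-oxazol-5-yl in place of oxetan-2-yl on a saturated chain carbon bound to an amine nitrogen in a ring.

The measured steps all vary a saturated oxygen ring at this position. Going to the smallest ring lowered the number modestly, a 2.6-fold lower number from compound 1 to compound 3 (0.42 log units; beyond the scatter) and a 5.2-fold lower number from compound 2 to compound 3 (0.72 log units; beyond the scatter), while a 2.0-fold higher number from compound 1 to compound 2 (0.30 log units; within the scatter) was within the scatter. None of them introduces an aromatic ring or a second acceptor, so they bear on compound 4 only by showing that this position tolerates change without large swings and that the larger rings gave higher numbers. A modest move upward from compound 3 is therefore expected, a 2.2-fold higher number from compound 3 to compound 4 (0.34 log units; beyond the scatter). Compound 4 is estimated at 50 nM, with a range from 18 nM to 150 nM.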

Compound 4, half-maximal inhibitory concentration: 120 nM
Compound 4: middle estimate off by 2.4-fold (0.38 log units), on the low side, within the range that was stated.
By their numbers in this assay, from the lowest: compound 3; then compounds 1, 2 and 4 (each within the scatter of the next).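

In this assay, 1,3-oxazol-5-yl, the only aromatic ring shown at this position, gives a 5.2-fold higher number from compound 3 to compound 4 (0.72 log units; beyond the scatter), which leaves oxetan-2-yl in compound 3 as the strongest inhibitor of the four, with its steps to all others beyond the scatter. The aromatic ring does not separate from the larger saturated rings: there is no change at the digits printed from compound 2 to compound 4 (within the scatter), and a 2.0-fold higher number from compound 1 to compound 4 (0.30 log units; within the scatter), so within this set only oxetan-2-yl stands apart. Nothing available explains why this ring stands apart.

Oxetan-3-yl at this position would test whether the low number follows the four-membered ring or its point of attachment. Phenyl, pyridin-2-yl or an open methoxyethyl chain would show whether the result for 1,3-oxazol-5-yl extends to other aromatic rings or to acyclic ethers.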